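Exchanging a chlorophenyl for a pyridinyl on a weak antiproliferative core

The source may hold more compounds than are shown below. What is called first, only, known or untested is meant among the compounds shown, and "the series" means these compounds.

Measured compounds:
compound 1, `c1ccc(-c2noc(-c3ccncc3)n2)cc1`, 657000 nM
compound 2, `COc1ccc(-c2noc(-c3ccc(Cl)cc3)n2)cc1OC1CCCC1`, 123000 nM
compound 3, `Fc1ccc(-c2nc(-c3ccccc3)no2)cc1`, > 1000000 nM

In a functional assay on DU-145 cells (Homo sapiens) for antiproliferative activity, read by MTT assay, with a stated time of 24 h (a lower number here means a stronger inhibitor, a higher number a weaker inhibitor), compound 2 gives 123000 nM, the lowest of the two numbers that are known. Compound 1 gives 657000 nM, a higher number than compound 2 by a margin beyond the scatter. For compound 3 the result is only a limit, (the limit of > 1000000 nM in this assay, at which 1 of the 3 values shown sits), and no number is reported. The unmeasured compound 4, `COc1ccc(-c2noc(-c3ccncc3)n2)cc1OC1CCCC1`, keeps the shared core of compound 2 and differs in one place: pyridin-4-yl in place of 4-chlorophenyl on an aromatic carbon. Among the compounds with values here, no measured pair shows this exact change, so its size cannot be read from the data. Compound 1, which also carries pyridin-4-yl, sits well above compound 2, but it differs from compound 2 in more than one place, so that gap is not attributed to any single change. Compound 4 is expected to give about 250000 nM in this assay, between 80000 nM and 800000 nM. That estimate means a step from compound 2 to compound 4 of a 2.0-fold higher number from compound 2 to compound 4 (0.31 log units; beyond the scatter), a modest rise toward weaker inhibition.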

Compound 4, half-maximal inhibitory concentration: > 1000000 nM
Compound 4: only a limit was reported; the forecaster's own chance of this, stated with the estimate: 15%; middle value at least 4.0-fold (0.60 log units) from the limit.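

Pyridin-4-yl in place of 4-chlorophenyl, on an aromatic carbon of a five-membered aromatic ring with 2 nitrogen and 1 oxygen, can now be read as a single change on the shared core, and in this assay it gives an at least 8.1-fold higher number from compound 2 to compound 4 (0.91 log units; beyond the scatter). For compound 4 the result is a limit and not a number, > 1000000 nM. The earlier compounds shown here could not isolate this position, but this pair shows that the weak activity of compound 2 does not survive the exchange, and the limit is no longer a single case: the limit of > 1000000 nM in this assay, at which 2 of the 4 values shown sit.

The compounds shown cannot separate the loss of the chlorine from the entry of the ring nitrogen. A plain phenyl, a 4-aminophenyl or a pyridin-3-yl at this place would bear on that question.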